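This account rests on a few compounds, and the source may have more. Where it says the series, first, only, none or still open, it means among the compounds named here.

Working notes on the triazole series in a functional assay on MCF7 cells (Homo sapiens) for antiproliferative activity, read by MTT assay, with a stated time of 24 h; a higher number here means a weaker inhibitor, a lower number a stronger inhibitor.

Compound 1 `O=C1NC(O)(CCn2cc(C3=CCCCC3)nn2)C(OCc2ccccc2)=C1OCc1ccccc1` carries a cyclohex-1-en-1-yl group on the triazole. In this assay compound 1 returns only a limit, > 100000 nM, not a number. Compound 2 `Cc1ccc(-c2cn(C/C=C3\OC(=O)C(OCc4ccccc4)=C3OCc3ccccc3)nn2)cc1` likewise returns only a limit in this assay, > 100000 nM. Compound 3 `COC1=C(OC)C(O)(CCn2cc(-c3ccccc3)nn2)NC1=O`, with a phenyl on the triazole and methoxy groups on the shared core, gives 22600 nM in this assay. Compound 1 therefore stands at the limit of > 100000 nM in this assay, at which 2 of the 3 values shown sit, with no number of its own to anchor a step.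

Compound 4 `O=C1NC(O)(CCn2cc(Cc3ccccc3)nn2)C(OCc2ccccc2)=C1OCc1ccccc1` differs from compound 1 in one place: benzyl in place of cyclohex-1-en-1-yl on an aromatic carbon. For the measured compounds named here, no step between measured compounds covers this change. Since compound 1 sits at a limit, only a move to a measurable value can be seen, not a loss. The step from compound 1 to compound 4 is estimated as an at least 1.6-fold lower number from compound 1 to compound 4 (0.22 log units; that floor lies within the scatter), with a real chance that compound 4 again sits at the limit. Compound 4 is expected near 60000 nM, within 15000 nM to 100000 nM.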

Compound 4, half-maximal inhibitory concentration: 39200 nM
Compound 4: middle estimate off by 1.5-fold (0.18 log units), on the high side, and the stated range covers the measured number.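

For the compounds shown here, replacing cyclohex-1-en-1-yl with benzyl on the aromatic carbon of the triazole gives the first readable step in this assay: an at least 2.5-fold lower number from compound 1 to compound 4 (0.40 log units; beyond the scatter). With the rest of the structure unchanged, this shows that the group at this position alone can move compound 1 off its limit, which compound 1, compound 2 and compound 3 could not show, as no two of them differ in one place. Compound 1 is only a limit, so the step gives a floor and not a size: the limit of > 100000 nM in this assay, at which 2 of the 4 values shown sit.

On these data alone, it remains open how phenyl directly on the triazole would read on the core of compound 4, as compound 3 carries phenyl alongside methoxy groups on the core. Also open, as far as these compounds go, is whether a longer chain such as phenethyl, or an amine or a carboxylic acid on the benzyl ring, would shift the number further.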